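A few compounds are considered here, and "the series" means these few. Any claim that something is new, unique, unknown or untested is made for them only; others in the source may bear on it.

Measured so far:
compound 1, `CC(C)c1noc(-c2cccc(CNc3ccc4[nH]nc(C(=O)O)c4c3)c2O)n1`: 227000 nM
compound 2, `CC(C)c1csc(-c2cccc(CN(C)c3ccc4[nH]nc(C(=O)O)c4c3)c2O)n1`: 6000 nM

In a physicochemical assay for solubility, measured as kinetic solubility, at pH 7.4 (a lower number here means a less soluble compound, a higher number a more soluble compound), compound 1 gives 227000 nM, the highest of the two numbers; compound 2 gives 6000 nM, a far lower number, beyond the scatter. Among the measured compounds shown here, compound 2 differs from compound 1 in more than one place, so the two values show only that the pair lies far apart, not which change carries that gap.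

Compound 3, `Cc1nc(-c2cccc(CNc3ccc4[nH]nc(C(=O)O)c4c3)c2O)sc1C`, has not yet been measured in this assay. Against compound 1 the change is 4,5-dimethyl-1,3-thiazol-2-yl in place of 3-isopropyl-1,2,4-oxadiazol-5-yl on an aromatic carbon, on an aromatic carbon of a six-membered aromatic ring of carbon only, ortho to a hydroxy group.

A downward step in this assay, of moderate size and beyond the scatter, is expected because compound 2, which also carries a 1,3-thiazol-2-yl ring at this place, gives 6000 nM. The step is estimated as a 4.5-fold lower number from compound 1 to compound 3 (0.66 log units; beyond the scatter). Compound 3 is therefore estimated at 50000 nM, with an expected range from 10000 nM to 200000 nM.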

Compound 3, solubility: 15000 nM
The estimate for compound 3 lay 3.3-fold (0.52 log units) above the measured number; measured number inside the range.
By their numbers in this assay, from the lowest: compound 2; then compound 3; then compound 1.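

Among the compounds shown here, replacing 3-isopropyl-1,2,4-oxadiazol-5-yl with 4,5-dimethyl-1,3-thiazol-2-yl, ortho to a hydroxy group, gives a 15-fold lower number from compound 1 to compound 3 (1.18 log units; beyond the scatter) in this assay, the first comparison that differs in one place only. The gap between compound 1 and compound 2 could not be assigned to any single place, whereas this pair shows that exchanging this substituent alone, with the rest of compound 1 unchanged, moves the number well beyond the scatter. Nothing at hand bears on why the number moves with this exchange.

The exchange alters the five-membered aromatic ring and its alkyl substituents together, so their shares remain unseparated, and compound 2 differs from compound 3 in more than one place, so no step can be read between them. Also open, going by these compounds, is how the number in this assay would respond at this position to a 1,2,4-oxadiazol-5-yl ring carrying an amine or a carboxylic acid in place of isopropyl.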